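Adding Chloro to the Core of Compound 2

A few compounds are considered here, and "the series" means these few. Any claim that something is new, unique, unknown or untested is made for them only; others in the source may bear on it.

Of the compounds shown here, three have been measured in a functional assay on SN12C cells (Homo sapiens) for cytotoxicity, read by sulforhodamine B assay, with a stated time of 48 h; a higher number here means a weaker inhibitor of growth, a lower number a stronger inhibitor of growth. Compound 1 `ClCc1ccc(Cn2cnc3nc(Cl)nc(Cl)c32)cc1` gives 3460 nM, compound 3 `ClCc1cccc(Cn2cnc3nc(Cl)nc(Cl)c32)c1` gives 2750 nM, and compound 2 `ClCc1ccccc1Cn1cnc2ncnc(Cl)c21` gives 8510 nM, the highest of the three numbers, beyond the scatter from both others. Compound 4 `ClCc1ccccc1Cn1cnc2nc(Cl)nc(Cl)c21` has not been measured. It differs from compound 2 by chloro in place of hydrogen on an aromatic carbon. Going by the values given here, compounds 1 and 3 share this chloro but differ from compound 2 in more than one place, so no clean single step is known. Because compound 1 gives 3460 nM and compound 3 gives 2750 nM, a modestly lower number is expected for compound 4, the step of a 2.1-fold lower number from compound 2 to compound 4 (0.33 log units; beyond the scatter). Compound 4 is estimated at 4000 nM, within 1500 nM to 10000 nM.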

Compound 4, concentration for total growth inhibition: 2570 nM
Beside the measured number, compound 4's estimate is 1.6-fold (0.19 log units) above it; measured number inside the range.
By their numbers in this assay, from the lowest: compounds 4, 3 and 1 (each within the scatter of the next); then compound 2.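

In this assay, going by these compounds alone, chloro in place of hydrogen on the aromatic carbon between two ring nitrogen atoms gives a 3.3-fold lower number from compound 2 to compound 4 (0.52 log units; beyond the scatter), the first clean reading of this single change. Within the data shown here, compounds 1 and 3 carry the same chloro but differ from compound 2 in more than one place, so only this pair isolates its effect on growth inhibition. Nothing measured here explains the stronger inhibition. As far as these compounds go, whether an amine or a methoxy group on this carbon would lower the number as well remains open.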